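A few compounds are considered here, and "the series" means these few. Any claim that something is new, unique, unknown or untested is made for them only; others in the source may bear on it.

Measured so far:
compound 1, `CN(C)CCCCCSC1=Nc2ccccc2C(CC(=O)NCc2ccccc2)N1c1ccc(-c2ccc(F)cc2)cc1`; in an assay on cells for inhibition of Voltage-dependent T-type calcium channel subunit alpha-1I (Homo sapiens), read by patch clamp, tested at 10 uM (a higher number here means more inhibition at the concentration tested (going by the name of the read-out), a lower number less inhibition), compound 1 gives 66.7%
compound 2, `CN(C)CCCCCSC1=Nc2ccccc2C(CC(=O)NCc2ccc(F)cc2)N1c1ccc(-c2ccccc2)cc1`; in this assay compound 2 gives 69.3%
compound 3, `CN(C)CCCCCSC1=Nc2ccccc2C(CC(=O)NCc2ccc(F)cc2)N1c1ccccc1`; in this assay compound 3 is reported as "not active" (no number reported)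

Compound 3 stands apart from the other two measured compounds: where compound 1 and compound 2 each carry a second aromatic ring on the aryl group attached to the core nitrogen and both give readings in the same band, compound 3 carries plain phenyl there and comes back with no number at all, only the note that it shows no inhibition in this assay. Compound 1 and compound 2 lie within the scatter of each other, so no order between them is claimed.

Compound 4, `CN(C)CCCCCSC1=Nc2ccccc2C(CC(=O)NCc2ccc(F)cc2)N1c1ccc(-c2ccc(F)cc2)cc1`, is the still unmeasured member of the series. It differs from compound 3 in one place: 4-fluorophenyl in place of hydrogen on an aromatic carbon. Among the measured compounds shown here, no measured step spans exactly this change, so the direction is read from the two pairs that bracket it. Compound 1 and compound 2 both hold a second aryl ring in this position and both fall in the same band, while compound 3, which lacks it, is reported as not active. The step from compound 3 to compound 4 is therefore expected to be a large gain in this assay, well beyond the scatter, taking the reading into the band shared by compound 1 and compound 2. For compound 4 the estimated value in this assay is 65%, with a range of 45% to 80%.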

Compound 4, a percentage reported as inhibition, at one concentration (the size of the read-out at that concentration, not a potency): 92%
Estimate against measurement, compound 4: 27 percentage points below, outside the stated range (above it).
By their numbers in this assay, from the lowest: compounds 1 and 2 (each within the scatter of the next); then compound 4.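

The result shows that the second aromatic ring alone does not fix the reading at this position, since the fluoro substitution pattern still matters once that ring is present. In this assay, fluoro in place of hydrogen on an aromatic carbon gives a number 22.7 percentage points higher from compound 2 to compound 4 (beyond the scatter), and the same change at a second place in the molecule gives a number 25.3 percentage points higher from compound 1 to compound 4 (beyond the scatter), so compound 4, which carries both fluoro groups, reads beyond the scatter of each partner with a single fluoro. The step from compound 3 to compound 4 cannot be read as a size because compound 3 has no number, and nothing available bears on what lies behind these gains.

Going by these compounds, what hydrogen at both fluoro places would give stays open, so whether the two fluoro groups contribute separately or only together cannot be told from these compounds. Also open, on these data alone, is whether chloro or methoxy in place of either fluoro, or a morpholine in place of the dimethylamino group, would hold a reading like that of compound 4 at 92%.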